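Methoxy to Phenyl: Predicting Compound 4

A few compounds are considered here, and "the series" means these few. Any claim that something is new, unique, unknown or untested is made for them only; others in the source may bear on it.

In a functional assay on MC-38 cells (Mus musculus) for antiproliferative activity, read by colorimetric assay and MTT assay (a higher number here means a weaker inhibitor, a lower number a stronger inhibitor), compound 3 `COc1ccc(NS(=O)(=O)c2ccc(N)cc2)c2[nH]cc(Cl)c12` gives the highest number of the three measured (2.3 ug/mL), which makes it the weakest inhibitor so far. Compound 1 `Nc1ccc(S(=O)(=O)Nc2ccc(Cl)c3c(Cl)c[nH]c23)cc1` reads 0.1 ug/mL and compound 2 `Nc1ccc(S(=O)(=O)Nc2ccc(Br)c3c(Cl)c[nH]c23)cc1` reads 0.14 ug/mL there, a gap within the scatter (a 1.4-fold higher number from compound 1 to compound 2 (0.15 log units; within the scatter)). Compound 4 `Nc1ccc(S(=O)(=O)Nc2ccc(-c3ccccc3)c3c(Cl)c[nH]c23)cc1` differs from compound 3 in one place (phenyl in place of methoxy on an aromatic carbon): phenyl in place of methoxy on an aromatic carbon. Methoxy in place of chloro gave a large step (a 23-fold higher number from compound 1 to compound 3 (1.36 log units; beyond the scatter)), and methoxy in place of bromo did too (a 16-fold higher number from compound 2 to compound 3 (1.22 log units; beyond the scatter)), so removing methoxy may lower the number. Within the data shown here, no measured compound carries phenyl, so only a modest step to a lower number is expected (a 2.3-fold lower number from compound 3 to compound 4 (0.36 log units; beyond the scatter)). Compound 4 is estimated at 1 ug/mL within a range (0.2 ug/mL to 5 ug/mL).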

Compound 4, half-maximal inhibitory concentration: 19 ug/mL
Compound 4: the middle estimate sits 19-fold (1.28 log units) below what was measured; measured number outside the range, above it.
By their numbers in this assay, from the lowest: compounds 1 and 2 (each within the scatter of the next); then compound 3; then compound 4.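

In this assay, replacing methoxy with phenyl raises the number rather than lowering it (an 8.3-fold higher number from compound 3 to compound 4 (0.92 log units; beyond the scatter)), and the steps from the halogen compounds are larger still (a 140-fold higher number from compound 2 to compound 4 (2.13 log units; beyond the scatter); a 190-fold higher number from compound 1 to compound 4 (2.28 log units; beyond the scatter)). Compound 4, carrying the only added ring at this position, is therefore the weakest inhibitor of the four, so this position does not accept every group equally. Nothing shown explains this loss. Going by these compounds, whether an amine, a carboxylic acid or a longer chain would be accepted here remains open, as does the effect of a fluoro group.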